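This account rests on a few compounds, and the source may have more. Where it says the series, first, only, none or still open, it means among the compounds named here.

Compound 1 `C=C1C(=O)O[C@H]2[C@H]1CC/C(COC(=O)CCC(=O)N1CCN(C(=O)Cn3cc(F)c(=O)[nH]c3=O)CC1)=C\CC[C@@]1(C)O[C@@H]21` reads > 20000 nM
Compound 2 `C=C1C(=O)O[C@H]2[C@H]1CC/C(Cn1cc(Cn3cc(F)c(=O)n(Cc4ccccc4)c3=O)nn1)=C\CC[C@@]1(C)O[C@@H]21` reads 9160 nM
Compound 3 `C=C1C(=O)O[C@H]2[C@H]1CC/C(COC(=O)Cn1cc(F)c(=O)n(Cc3ccc(F)cc3)c1=O)=C\CC[C@@]1(C)O[C@@H]21` reads 2730 nM

The reading for compound 1 is a limit of a functional assay on Bel-7402 cells (Homo sapiens) for antiproliferative activity, read by MTT assay, with a stated time of 72 h (a higher number here means a weaker inhibitor, a lower number a stronger inhibitor), and not a number. Of the two actual numbers, compound 3 has the lower, and its gap to compound 2 lies beyond the scatter.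

Compound 4 `C=C1C(=O)O[C@H]2[C@H]1CC/C(COC(=O)Cn1cc(F)c(=O)n(Cc3ccc(F)cc3F)c1=O)=C\CC[C@@]1(C)O[C@@H]21` carries one change from compound 3: fluoro in place of hydrogen on an aromatic carbon in short, fluoro in place of hydrogen on an aromatic carbon, with 4-fluorobenzyl becoming 2,4-difluorobenzyl. Going by the values given here, no measured pair in this set shows such a change, so the data fix no direction, and no step beyond the scatter is expected in this assay for this replacement. The expected step of a 1.1-fold lower number from compound 3 to compound 4 (0.04 log units; within the scatter) is small. The expectation rests on compound 3 at 2730 nM as the closest measured structure. For compound 4 the estimated value is 2500 nM with an expected range from 1000 nM to 6500 nM in this read-out.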

Compound 4, half-maximal inhibitory concentration: 3670 nM
Compound 4: middle estimate off by 1.5-fold (0.17 log units), on the low side; the range from low to high includes it.
By their numbers in this assay, from the lowest: compounds 3 and 4 (each within the scatter of the next); then compound 2. At a limit, above all of these: compound 1.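

In this assay, fluoro on the aromatic carbon ortho to a large group, with 4-fluorobenzyl becoming 2,4-difluorobenzyl, gives a 1.3-fold higher number from compound 3 to compound 4 (0.13 log units; within the scatter). Going by these compounds alone, this is the first reading at this position, and on this ester-linked series the ring takes a second fluoro without a step that can be told from the scatter, so compounds 3 and 4 stand level in this read-out. Nothing in the information at hand accounts for the size of this step.

Open, as far as these compounds go, is whether a larger group on the same aromatic carbon, such as methoxy, trifluoromethyl or an amine, would give a step beyond the scatter. Also open, from the compounds shown here alone, is how a plain benzyl group would read on the linker of compound 3, and whether the same fluoro change would read alike on the linker of compound 2.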